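A few compounds are considered here, and "the series" means these few. Any claim that something is new, unique, unknown or untested is made for them only; others in the source may bear on it.

Measured compounds:
compound 1 `CCc1ccc(-c2cc(Cl)cc(C(=O)Nc3nn[nH]n3)n2)cc1` — 49%
compound 2 `COc1cc(C(=O)Nc2nn[nH]n2)nc(-c2ccccc2)c1` — 62%

In a functional assay on the whole organism with Rattus norvegicus as the target, at a dose of 1 mg/kg by the oral route (on this read-out lower numbers stand for a weaker effect and higher numbers for a stronger effect at the one dose given), compound 1 gives 49%, while compound 2 gives 62%. Compound 2 thus stands highest of the two numbers, and its gap to compound 1 lies beyond the usual scatter; as the two compounds differ in more than one place, no single structural step can be read from them.

Compound 3 `COc1cc(C(=O)Nc2nn[nH]n2)nc(-c2ccc(N(C)C)cc2)c1` has not yet been tested in this assay. It differs from compound 2 in one place, (dimethylamino in place of hydrogen on an aromatic carbon), the new group sitting on an aromatic carbon of a six-membered aromatic ring of carbon only. Within the data shown here, no measured pair shows what such a change does here, so the expected step from compound 2 to compound 3 is set small, within the scatter, as a number 3 percentage points higher from compound 2 to compound 3 (within the scatter). Compound 3 is therefore estimated at 65%, with a likely range from 45% to 85%.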

Compound 3, a percentage reported as inhibition, in the whole organism at one dose (the size of the read-out at that dose, not a potency): 64%
Beside the measured number, compound 3's estimate is 1 percentage points above it; the range from low to high includes it.
By their numbers in this assay, from the lowest: compound 1; then compounds 2 and 3 (each within the scatter of the next).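

In this assay, the one single-place change shown comes out as a number 2 percentage points higher from compound 2 to compound 3 (within the scatter). Dimethylamino in place of hydrogen, on an aromatic carbon of a six-membered aromatic ring of carbon only and para to a large group, therefore adds 3 heavy atoms at this position with no shift in the read-out beyond the scatter. Nothing measured here accounts for this outcome.

As far as these compounds go, whether a carboxylic acid, a primary amine or a longer chain at the same position would also leave the read-out within the scatter remains open. Compound 1 differs from compound 2 in more than one place, so the separate contributions of its ethyl group and its chlorine cannot be read.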